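Dimethylamino for methyl on the core of compound 2

The compounds below may be only part of what the source reports. "The series", "measured", "known", "first", "only" and "open" are said of these compounds alone.

Measured compounds:
compound 1, `Fc1ccc2nc(-c3cncs3)n(C3CC3)c2c1`, 62 nM
compound 2, `Cc1ncncc1-c1nc2cc(F)c(F)cc2n1C1CC1`, 17 nM

In an assay on cells for inhibition of cytochrome P450 11B2, mitochondrial (Homo sapiens), read by HPLC, with a stated time of 90 min (a higher number here means a weaker inhibitor, a lower number a stronger inhibitor), compound 2 gives 17 nM, the lowest of the two numbers; compound 1 gives 62 nM, a gap beyond the scatter. Compound 3, `CN(C)c1ncncc1-c1nc2cc(F)c(F)cc2n1C1CC1`, differs from compound 2 by dimethylamino in place of methyl on an aromatic carbon, a dimethylamino in place of methyl on an aromatic carbon. Going by the values given here, no measured pair shows this change, so only a small step is expected, with no clear direction beyond the scatter, perhaps a slight weakening. The step from compound 2 to compound 3 is estimated at a 1.8-fold higher number from compound 2 to compound 3 (0.25 log units; within the scatter). For compound 3 the expected value in this assay is 30 nM, within 8 nM to 120 nM.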

Compound 3, half-maximal inhibitory concentration: 29 nM
Beside the measured number, compound 3's estimate is 1.0-fold (0.01 log units) above it, within the range that was stated.
By their numbers in this assay, from the lowest: compounds 2 and 3 (each within the scatter of the next); then compound 1.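

In this assay the change of methyl to dimethylamino gives a 1.7-fold higher number from compound 2 to compound 3 (0.23 log units; within the scatter) at this aromatic carbon next to the ring nitrogen. Going by these compounds alone, the position therefore takes dimethylamino in place of methyl with no step beyond the scatter, something the earlier compounds, which shared no such pair, could not show. Nothing available here bears on the reason for this result.

Still open, from the compounds shown here alone, is how methylamino, morpholine or methoxy would read at this position. Going by these compounds, it is also open whether dimethylamino would give a similar step on the core of compound 1.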